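The compounds below may be only part of what the source reports. "The series", "measured", "known", "first", "only" and "open" are said of these compounds alone.

Measured compounds in a functional assay on A549 cells (Homo sapiens) for inhibition, read by MTT assay, with a stated time of 24 h; on this read-out lower numbers stand for stronger inhibition and higher numbers for weaker inhibition:
compound 1 `COc1ccccc1-n1cc(CN2C(=O)C[C@@H]3CC[C@@]2(C)C3(C)C)nn1` gives 350 nM;
compound 2 `CC1(C)[C@H]2CC[C@]1(C)N(Cc1cn(-c3ccccc3)nn1)C(=O)C2` gives 70 nM;
compound 3 `CC1(C)[C@H]2CC[C@]1(C)N(Cc1cn(-c3cccc(Br)c3)nn1)C(=O)C2` gives 90 nM.

Compound 1 has the highest number of the three, beyond the scatter from both compound 2 and compound 3. Compound 4 `CC1(C)[C@H]2CC[C@]1(C)N(Cc1cn(-c3ccc(Cl)cc3)nn1)C(=O)C2` differs from compound 1 as follows: 4-chlorophenyl in place of 2-methoxyphenyl on an aromatic nitrogen. Among the measured compounds shown here, two measured steps bear on this. Removing the methoxy gave a 5.0-fold lower number from compound 1 to compound 2 (0.70 log units; beyond the scatter), and exchanging the whole aryl gave a 3.9-fold lower number from compound 1 to compound 3 (0.59 log units; beyond the scatter); between those two products the added halogen changed little, a 1.3-fold higher number from compound 2 to compound 3 (0.11 log units; within the scatter). Compound 4 likewise lacks the methoxy and carries a halogen on the phenyl, so a downward step of similar size is expected, a 4.4-fold lower number from compound 1 to compound 4 (0.64 log units; beyond the scatter). For compound 4 the expected value is 80 nM, within 40 nM to 160 nM.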

Compound 4, half-maximal inhibitory concentration: 70 nM
For compound 4 the middle estimate is 1.1-fold (0.06 log units) above the measured one; the range from low to high includes it.
By their numbers in this assay, from the lowest: compounds 2, 4 and 3 (each within the scatter of the next); then compound 1.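

In this assay, the new change gives a 5.0-fold lower number from compound 1 to compound 4 (0.70 log units; beyond the scatter), which shows that the low number does not depend on a bromo group or on 3-bromophenyl: 4-chlorophenyl on the aromatic nitrogen also gives it. With a 1.3-fold lower number from compound 3 to compound 4 (0.11 log units; within the scatter) and no change at the digits printed from compound 2 to compound 4 (within the scatter), the phenyl, 3-bromophenyl and 4-chlorophenyl compounds cannot be told apart, and only compound 1 stands off from them. Nothing at hand explains this flat response. From the compounds shown here alone, it remains open whether the higher number of compound 1 follows the methoxy group itself or its place in 2-methoxyphenyl. Going by these compounds, how an amine or a carboxylic acid on the phenyl would read is also open.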